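A Side-Chain Swap Close to the Assay Limit

This account rests on a few compounds, and the source may have more. Where it says the series, first, only, none or still open, it means among the compounds named here.

Going by the values given here, in a functional assay on MDA-MB-468 cells (Homo sapiens) for antiproliferative activity, read by MTT assay, with a stated time of 24 h (a lower number here means a stronger inhibitor, a higher number a weaker inhibitor), compound 2 (`COc1cc(Nc2nccc(NCCCN)n2)cc(OC)c1OC`) gives 45800 nM and holds the only true number in this small set. Compound 1 (`CNC(=O)c1ccccc1Oc1nc(Nc2ccc(Cl)cc2F)ncc1Br`) reads > 50000 nM as a limit and not a number. Compound 3 (`COc1cc(Nc2ncc(I)c(NCCCN)n2)cc(OC)c1OC`) likewise reports only a limit at > 50000 nM and no number.

Compound 4 (`CCN(CC)CCNc1ccnc(Nc2cc(OC)c(OC)c(OC)c2)n1`) keeps the core of compound 2 and alters its side chain (diethylamino in place of aminomethyl on a saturated chain carbon, two bonds along the chain from a nitrogen on an aromatic ring). Among the compounds with values here, the one measured step (an at least 1.0-fold higher number from compound 2 to compound 3 (0.03 log units; that floor lies within the scatter)) is iodo in place of hydrogen on an aromatic carbon, so it sits elsewhere on the molecule and stays within the scatter. Within the data shown here, no measurement yet tests a change on this chain.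

The starting point is therefore compound 2 at 45800 nM and no large move in either direction is expected. The expected step (a 1.1-fold lower number from compound 2 to compound 4 (0.06 log units; within the scatter)) is estimated to stay within the scatter in this assay and a reading at the limit would be no surprise. Compound 4 is estimated at about 40000 nM (expected range 15000 nM to 60000 nM).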

Compound 4, half-maximal inhibitory concentration: > 50000 nM
Compound 4 gave a limit, no number (the forecaster's own chance of this, stated with the estimate: 40%); at least 1.2-fold (0.09 log units) between middle value and limit.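

In this assay compound 4 gives > 50000 nM, which is a limit of the assay and not a number. Going by these compounds alone, this is the first test of a change on the side chain, and the step reads an at least 1.0-fold higher number from compound 2 to compound 4 (0.03 log units; that floor lies within the scatter), so diethylamino in place of aminomethyl at this chain carbon gives no lower number. How large the change really is cannot be read, because most of this small set stands at the same limit: the limit of > 50000 nM in this assay, at which 3 of the 4 values shown sit.

On these data alone, it remains open whether a longer chain, a piperidine or morpholine ring at the chain end, or a carboxylic acid there would bring the number down. Within the data shown here, compound 2 still holds the only true number, so the real size of any step on this chain is also unknown.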